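Spiro amide orexin-2 antagonists: aryl-amine swap

This account rests on a few compounds, and the source may have more. Where it says the series, first, only, none or still open, it means among the compounds named here.

Measured compounds:
- compound 1, `Cc1ccc(-c2ncccn2)c(C(=O)N2CCC3(CC3)C[C@H]2CNc2ccc(Cl)cn2)c1`: < 5
- compound 2, `Cc1nc(C(=O)N2CC3(CC3)C[C@H]2CNc2ncc(Cl)cn2)c(-c2ccccc2)s1`: 6.8
- compound 3, `O=C(c1nc(C(F)(F)F)ccc1-c1ncccn1)N1CC2(CC2)C[C@H]1CNc1ccc(C(F)(F)F)cn1`: 5

In a functional assay on HEK293 cells for antagonist activity at Orexin receptor type 2 (Homo sapiens), read by FLIPR and calcium flux (on this read-out lower numbers stand for lower potency and higher numbers for higher potency (the scale is a negative logarithm)), compound 2 gives 6.8 and stands as the higher of the two numbers obtained. Compound 3 gives 5, a value lower than that of compound 2, a gap beyond the scatter. For compound 1 the result is a limit of the assay, < 5, not a number; (the limit of < 5 in this assay, at which 1 of the 3 values shown sits).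

The next compound, compound 4, `Cc1cc(C(F)(F)F)cc(NC[C@@H]2CC3(CC3)CN2C(=O)c2nc(C)sc2-c2ccccc2)n1`, has yet to be measured in this assay. It differs from compound 2 in one place: 6-methyl-4-(trifluoromethyl)pyridin-2-yl in place of 5-chloropyrimidin-2-yl on an amine nitrogen. For the measured compounds named here, no measured pair shows this kind of change, so there is no step to draw on. The expectation is that the change from the 5-chloropyrimidin-2-yl to the 6-methyl-4-(trifluoromethyl)pyridin-2-yl on the amine nitrogen gives no step beyond the scatter in this assay, the rest of compound 2 being kept. Compound 4 is therefore estimated at 6.9, with a range from 6 to 7.7. The estimated step of a number 0.10 log units higher from compound 2 to compound 4 (within the scatter) is expected to sit within the scatter of repeated measurements.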

Compound 4, negative logarithm of the antagonist equilibrium constant: 8.6
The estimate for compound 4 lay 1.70 log units below the measured number; the whole stated range lies below it.
By their numbers in this assay, from the lowest: compound 3; then compound 2; then compound 4.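

On the amine nitrogen of the shared core, 6-methyl-4-(trifluoromethyl)pyridin-2-yl in place of 5-chloropyrimidin-2-yl gives a number 1.80 log units higher from compound 2 to compound 4 (beyond the scatter) in this assay, which marks this position as one where a single change moves the read-out strongly. For the compounds shown here, compound 1, compound 2 and compound 3 differ from one another in more than one place, so the earlier values could not isolate this position, and this pair is the first to do so. The change alters several things at once, as chlorine leaves, methyl and trifluoromethyl enter and the ring loses a hetero atom, and no measurement at hand bears on which of these accounts for the step.

Still open, on these data alone, is how the step divides between the methyl and the trifluoromethyl group, a question that an unsubstituted pyridin-2-yl, or a nitrile or methoxy group in place of the trifluoromethyl, would address. Also open, as far as these compounds go, is whether the same aryl group on the amine nitrogen gives a comparable step when carried on the amide parts of compound 1 and compound 3.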